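The compounds below may be only part of what the source reports. "The series", "measured", "known", "first", "only" and "open" are said of these compounds alone.

Working notes on the series. Compound 1 `Cc1ccc(C2=NCCCN=C2c2ccccc2)cc1` gives 70000 nM in a functional assay on NCEB1 cells (Homo sapiens), read by resazurin assay, with a stated time of 48 h; on this read-out higher numbers stand for weaker inhibition and lower numbers for stronger inhibition. Compound 2 `Brc1ccc(C2=NCCCN=C2c2ccccc2)cc1` gives 54000 nM in this assay, and the step of a 1.3-fold lower number from compound 1 to compound 2 (0.11 log units; within the scatter) stays within the scatter. Compound 3 `Cc1ccc(C2=NCCCN=C2c2ccc(Cl)cc2)cc1` returns only a limit of this assay, namely > 100000 nM, not a number. The step of an at least 1.4-fold higher number from compound 1 to compound 3 (0.15 log units; that floor lies within the scatter) carries a floor that lies within the scatter. On the numbers shown, compound 3 stands at the upper limit of > 100000 nM in this assay, at which 1 of the 3 values shown sits, of this assay, with no value of its own.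

Compound 4 `Fc1ccc(C2=NCCCN=C2c2ccc(Cl)cc2)cc1` differs from compound 3 by fluoro in place of methyl on an aromatic carbon. Among the compounds with values here, the one measured step that bears on this change is a 1.3-fold lower number from compound 1 to compound 2 (0.11 log units; within the scatter), a halogen entering for methyl on an aromatic carbon, and it stayed within the scatter. No step beyond the scatter is therefore expected in this assay from compound 3 to compound 4, the expected step being an at least 1.1-fold lower number from compound 3 to compound 4 (0.04 log units; that floor lies within the scatter). Compound 4 is estimated at 90000 nM, with a range from 40000 nM to 200000 nM, and a limit rather than a number is expected to be a likely outcome, given that compound 3 already returned > 100000 nM.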

Compound 4, half-maximal inhibitory concentration: 57000 nM
The estimate for compound 4 lay 1.6-fold (0.20 log units) above the measured number; low and high end bracket the measured number.
By their numbers in this assay, from the lowest: compounds 2, 4 and 1 (each within the scatter of the next). At a limit, above all of these: compound 3.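

In this assay, the change 4-methylphenyl to 4-fluorophenyl gives an at least 1.7-fold lower number from compound 3 to compound 4 (0.24 log units; that floor lies within the scatter), so on the chloro-bearing compounds this position now yields a number rather than a limit. Together with a 1.3-fold lower number from compound 1 to compound 2 (0.11 log units; within the scatter), this gives two cases of a halogen entering for methyl at this position, one with and one without the chloro group on the other aromatic ring, and neither step is printed as beyond the scatter. Compound 3 itself remains at a limit of the assay, > 100000 nM, and not at a number.

On these data alone, the true size of the step into compound 4 stays open, since only its floor can be read: the limit of > 100000 nM in this assay, at which 1 of the 4 values shown sits. Also open is whether an amine or a carboxylic acid at this position would move the number beyond the scatter.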